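This account rests on a few compounds, and the source may have more. Where it says the series, first, only, none or still open, it means among the compounds named here.

Measured so far:
compound 1 `FC(F)(F)c1ccc(CN2CCN(Cc3cc(-c4ccc(OCc5ccccc5)cc4)on3)CC2)cc1` — a functional assay on Mahlavu cells (Homo sapiens) for antiproliferative activity, read by sulforhodamine B assay, with a stated time of 72 h; on this read-out higher numbers stand for weaker inhibition and lower numbers for stronger inhibition: 11700 nM
compound 2 `Cc1cccc(COc2ccc(-c3cc(CN4CCN(Cc5ccc(C(F)(F)F)cc5)CC4)no3)cc2)c1` — this assay: 2500 nM

Going by the values given here, compound 2 stands lowest of the two numbers; the only step measured in the set, a 4.7-fold lower number from compound 1 to compound 2 (0.67 log units; beyond the scatter), separates it from compound 1. Compound 3 `Fc1ccccc1COc1ccc(-c2cc(CN3CCN(Cc4ccc(C(F)(F)F)cc4)CC3)no2)cc1` carries 2-fluorophenyl in place of 3-methylphenyl on a saturated chain carbon bound to an oxygen on an aromatic ring. Among the compounds with values here, no measured step covers this exchange: the single step known concerns methyl in place of hydrogen and says nothing about fluorine or about a shifted ring position, so direction is open. For compound 3 a modest step upward is expected, a 2.4-fold higher number from compound 2 to compound 3 (0.38 log units; beyond the scatter), with wide uncertainty. The estimate for compound 3 is 6000 nM, range 2000 nM to 18000 nM.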

Compound 3, half-maximal inhibitory concentration: 3100 nM
For compound 3 the middle estimate is 1.9-fold (0.29 log units) above the measured one, within the range that was stated.
By their numbers in this assay, from the lowest: compounds 2 and 3 (each within the scatter of the next); then compound 1.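

In this assay, 2-fluorophenyl and 3-methylphenyl on this saturated chain carbon cannot be told apart: a 1.2-fold higher number from compound 2 to compound 3 (0.09 log units; within the scatter). A single fluorine added to the unsubstituted ring also gives a modest drop, a 3.8-fold lower number from compound 1 to compound 3 (0.58 log units; beyond the scatter), so a lower number at this ring is no longer tied to methyl alone. No measurement at hand speaks to a cause. Compounds 2 and 3 differ in both substituent and its ring position, leaving the two unseparated; 3-fluorophenyl or 2-methylphenyl would address this. Going by these compounds, whether an amine or a carboxylic acid on this ring would keep the number also stays open.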